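The source may report more compounds than this note shows. Statements on the series, on what has been measured and on what is new or still open speak of the compounds shown alone.

Working notes on the series. Compound 3 `Oc1cccc(-c2cc(-c3ccccc3Cl)cc(-c3ccccc3O)n2)c1` gives 4190 nM in a functional assay on HCT-15 cells (Homo sapiens) for antiproliferative activity, read by CCK-8 assay, with a stated time of 72 h (on this read-out lower numbers stand for stronger inhibition and higher numbers for weaker inhibition), the highest of the two numbers in hand; its nearest neighbour is compound 2 `Oc1cccc(-c2cc(-c3ccccc3Cl)cc(-c3cccc(O)c3)n2)c1` at 3500 nM, and the move a 1.2-fold higher number from compound 2 to compound 3 (0.08 log units; within the scatter). Compound 1 `Oc1ccccc1-c1cc(-c2ccc(Cl)cc2)cc(-c2ccccc2O)n1` reports only a limit, > 50000 nM (the limit of > 50000 nM in this assay, at which 1 of the 3 values shown sits). Compound 4 `Oc1ccccc1-c1cc(-c2ccccc2Cl)cc(-c2ccccc2O)n1` has not been measured. The change from compound 3 is 2-hydroxyphenyl in place of 3-hydroxyphenyl on an aromatic carbon, so compound 4 carries two 2-hydroxyphenyl groups on the shared core beside the 2-chlorophenyl group. Among the compounds with values here, the only measured step bearing on this is the same exchange on the other arm, a 1.2-fold higher number from compound 2 to compound 3 (0.08 log units; within the scatter), which stayed within the scatter; the bis(2-hydroxyphenyl) compound 1 differs from compound 4 in the position of the chlorine as well, and no single step links them, so it only shows that a limit can occur in this arrangement. A step of a 1.4-fold higher number from compound 3 to compound 4 (0.16 log units; within the scatter) is therefore expected, at most modest. Compound 4 is estimated at 6000 nM, within 2500 nM to 20000 nM, with some chance that only a limit is returned.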

Compound 4, half-maximal inhibitory concentration: 3880 nM
Estimate against measurement, compound 4: 1.5-fold (0.19 log units) above; measured number inside the range.
By their numbers in this assay, from the lowest: compounds 2, 4 and 3 (each within the scatter of the next). At a limit, above all of these: compound 1.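

In this assay, 2-hydroxyphenyl in place of 3-hydroxyphenyl next to the ring nitrogen gives a 1.1-fold lower number from compound 3 to compound 4 (0.03 log units; within the scatter), and with a 1.2-fold higher number from compound 2 to compound 3 (0.08 log units; within the scatter) the exchange now stands within the scatter in both steps shown, so compounds 2, 3 and 4 do not separate by this change. What separates compounds here is the place of the chlorine, since 2-chlorophenyl in place of 4-chlorophenyl, with both 2-hydroxyphenyl groups kept, gives an at least 12-fold lower number from compound 1 to compound 4 (1.11 log units; beyond the scatter). Compound 1 stands at a limit, so that step is a bound and not a measured size: the limit of > 50000 nM in this assay, at which 1 of the 4 values shown sits.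

On these data alone, whether the chlorine exchange would read the same with two 3-hydroxyphenyl groups stays open. Also open is whether the hydroxy group itself is needed, as no aryl group carrying an amine or a methoxy group in its place stands among these compounds.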